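This account rests on a few compounds, and the source may have more. Where it says the series, first, only, none or still open, it means among the compounds named here.

Compound 3 `COc1ccc(S(=O)(=O)N2CCc3cccc(NC(=O)c4ccc(F)cc4)c32)cc1` gives 45 nM in a functional assay on MKN-45 cells (Homo sapiens) for cytotoxicity; a higher number here means a weaker inhibitor, a lower number a stronger inhibitor. Among the three compounds measured, compound 3 has the second highest number: compound 1 `COc1ccc(S(=O)(=O)N2CCc3cccc(NC(=O)c4ccc(C#N)cc4)c32)cc1` gives 89 nM, and the step of a 2.0-fold lower number from compound 1 to compound 3 (0.30 log units; within the scatter) lies within the scatter, while compound 2 `COc1ccc(S(=O)(=O)N2CCc3cccc(NC(=O)c4ccncc4)c32)cc1` gives 8.8 nM, and the step of a 5.1-fold higher number from compound 2 to compound 3 (0.71 log units; beyond the scatter) lies beyond it. The change to compound 4 `COc1ccc(S(=O)(=O)N2CCc3cccc(NC(=O)c4ccccc4)c32)cc1` is hydrogen in place of fluoro on an aromatic carbon. Within the data shown here, the step of a 2.0-fold lower number from compound 1 to compound 3 (0.30 log units; within the scatter), which also altered the group at the same place, stayed within the scatter, and no measured step swaps fluoro for hydrogen; the larger steps of a 10-fold lower number from compound 1 to compound 2 (1.00 log units; beyond the scatter) and a 5.1-fold higher number from compound 2 to compound 3 (0.71 log units; beyond the scatter) concern exchange of the whole ring. A step of a 1.2-fold higher number from compound 3 to compound 4 (0.09 log units; within the scatter) is therefore expected, not beyond the scatter. Compound 4 is estimated at 55 nM, between 20 nM and 150 nM.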

Compound 4, half-maximal inhibitory concentration: 250 nM
Estimate against measurement, compound 4: 4.5-fold (0.66 log units) below; the whole stated range lies below it.
By their numbers in this assay, from the lowest: compound 2; then compounds 3 and 1 (each within the scatter of the next); then compound 4.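

In this assay this ring position proves sensitive to a single atom, since hydrogen in place of fluoro is a step beyond the scatter (a 5.6-fold higher number from compound 3 to compound 4 (0.74 log units; beyond the scatter)). Replacing cyano with hydrogen at the same place also goes beyond the scatter (a 2.8-fold higher number from compound 1 to compound 4 (0.45 log units; beyond the scatter)), so the unsubstituted benzamide carries the higher number against both para-substituted rings, and the largest step is the exchange of pyridin-4-yl for phenyl (a 28-fold higher number from compound 2 to compound 4 (1.45 log units; beyond the scatter)). Nothing available explains these differences. From the compounds shown here alone, how an amine or a carboxylic acid at this place would read remains open.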